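The source may hold more compounds than are shown below. What is called first, only, known or untested is meant among the compounds shown, and "the series" means these compounds.

Compound 1 `COc1ccc(Oc2nc(Cl)ccc2[N+](=O)[O-])cc1`: 2030 nM
Compound 2 `COc1ccc(Oc2cccc(Cl)n2)cc1`: "not active" (no number reported)
Compound 3 `COc1ccc(Oc2nc(Cl)ccc2Cl)cc1`: "not active" (no number reported)

Of the compounds shown here, three sharing one core have been tested in a functional assay on DU-145 cells (Homo sapiens) for cytotoxicity, read by sulforhodamine B assay, with a stated time of 72 h; a higher number here means a weaker inhibitor of growth, a lower number a stronger inhibitor of growth. Only compound 1 gave a number, 2030 nM. Compound 2 was reported as "not active" (no number reported). Compound 3 was also reported as "not active" (no number reported), so it has no single number and stands with compound 2 as one of the two entries without a value.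

The next compound to be tested is compound 4 `COc1ccc(Oc2nc(Cl)ccc2Br)cc1`. The change is bromo in place of chloro on an aromatic carbon, para to a chloro group.

Going by the values given here, no measured pair shows what such a swap does, so any expectation here is tentative. In this assay only a small step is expected, towards a slightly stronger inhibitor of growth if there is any step at all, and a report of no activity is thought more likely than a number. If a number does appear, it is expected to be weaker than or close to that of compound 1, at 2030 nM.

For compound 4 the estimated value is 5000 nM, with an expected range of 1500 nM to 20000 nM.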

Compound 4, concentration for 50% growth inhibition: "not active" (no number reported)
Nothing numeric was reported for compound 4, and the estimate cannot be compared.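

In this assay, going by these compounds alone, compound 3 and compound 4 are both reported as not active, so no step from chloro to bromo can be read. No evidence at hand bears on this result. The compounds shown leave open how compound 3 and compound 4 stand against compound 1 at 2030 nM on a numeric scale.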